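Thiophen-3-yl Replacing Pyridin-2-yl on the Shared Core

The source may hold more compounds than are shown below. What is called first, only, known or untested is meant among the compounds shown, and "the series" means these compounds.

In a functional assay on MCF7 cells (Homo sapiens) for antiproliferative activity, read by MTT assay, with a stated time of 48 h (on this read-out lower numbers stand for stronger inhibition and higher numbers for weaker inhibition), compound 1 `CC(=O)N1N=C(c2ccc3ccccc3c2)OC1c1ccccc1O` gives 2.12 ug/mL, while compound 2 `CC(=O)N1N=C(c2ccc3ccccc3c2)OC1c1ccccn1` gives 6.02 ug/mL, the higher of the two numbers. Compound 3 `CC(=O)N1N=C(c2ccc3ccccc3c2)OC1c1ccsc1` carries thiophen-3-yl in place of pyridin-2-yl on a saturated ring carbon. For the measured compounds named here, the only measured step at that carbon, a 2.8-fold higher number from compound 1 to compound 2 (0.45 log units; beyond the scatter), was modest and involved a different pair of groups. It therefore offers only weak guidance, and no change beyond the scatter is expected in either direction. The estimated step is a 1.2-fold lower number from compound 2 to compound 3 (0.08 log units; within the scatter). For compound 3, the expected value in this assay is 5 ug/mL, with an estimated range of 1.8 ug/mL to 14 ug/mL.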

Compound 3, half-maximal inhibitory concentration: 7.98 ug/mL
Beside the measured number, compound 3's estimate is 1.6-fold (0.20 log units) below it; the measured number falls inside the stated range.
By their numbers in this assay, from the lowest: compound 1; then compounds 2 and 3 (each within the scatter of the next).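

At this saturated ring carbon, thiophen-3-yl in place of pyridin-2-yl gives a 1.3-fold higher number from compound 2 to compound 3 (0.12 log units; within the scatter) in this assay, so exchanging a six-membered aromatic ring with nitrogen for a five-membered one with sulfur leaves the read-out within the scatter. Thiophen-3-yl in place of 2-hydroxyphenyl gives a 3.8-fold higher number from compound 1 to compound 3 (0.58 log units; beyond the scatter), leaving 2-hydroxyphenyl as the only group of the three set apart from the others. Nothing available explains these numbers.

The compounds shown leave open how a methoxyphenyl or an aminophenyl group would read at this carbon. They also leave open whether the hydroxyl of 2-hydroxyphenyl accounts for the lower number of compound 1.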